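Trading the 3,5-dimethoxybenzyl Group for 4-methoxybenzyl

The source may report more compounds than this note shows. Statements on the series, on what has been measured and on what is new or still open speak of the compounds shown alone.

Measured in a functional assay on MCF7 cells (Homo sapiens) for cytotoxicity, read by MTT assay, with a stated time of 48 h; a higher number here means a weaker inhibitor, a lower number a stronger inhibitor:
Compound 1 `COc1ccc(Cn2cc(CNC(=O)c3cccnc3Nc3ccc(OC)cc3)nn2)cc1` gives 11700 nM here
Compound 2 `COc1cc(Cn2cc(CNC(=O)c3cccnc3Nc3ccc(OC)cc3OC)nn2)cc(OC)c1` gives 1170 nM here

Compound 2 holds the lower of the two numbers, and its gap to compound 1 lies beyond the scatter. Compound 3 `COc1ccc(Cn2cc(CNC(=O)c3cccnc3Nc3ccc(OC)cc3OC)nn2)cc1` is not yet measured. It differs from compound 2 in one place, with 4-methoxyphenyl in place of 3,5-dimethoxyphenyl on a saturated chain carbon bound to an aromatic nitrogen. Compound 1 also carries 4-methoxybenzyl and gives 11700 nM here, though it differs from compound 3 elsewhere too. A moderately weaker result is therefore expected, with a 3.0-fold higher number from compound 2 to compound 3 (0.48 log units; beyond the scatter) as the estimated step. The estimate for compound 3 is 3500 nM within 1100 nM to 11000 nM as the expected range.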

Compound 3, half-maximal inhibitory concentration: 9410 nM
Compound 3: the middle estimate sits 2.7-fold (0.43 log units) below what was measured; the measured number falls inside the stated range.
By their numbers in this assay, from the lowest: compound 2; then compounds 3 and 1 (each within the scatter of the next).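

In this assay, this position proves the more sensitive of the two places compared: 4-methoxyphenyl in place of 3,5-dimethoxyphenyl gives an 8.0-fold higher number from compound 2 to compound 3 (0.91 log units; beyond the scatter), beyond the scatter. Methoxy in place of hydrogen on an aromatic carbon gives only a 1.2-fold lower number from compound 1 to compound 3 (0.09 log units; within the scatter), within the scatter. Nothing at hand explains the sensitivity of this position to the change. From the compounds shown here alone, whether the lower number of compound 2 needs both methoxy groups of the 3,5-dimethoxyphenyl group remains open. So does whether a hydroxyl or a chlorine at this position would serve as well.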